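Bromo for isopropyl on the aryl ring of compound 1

This account rests on a few compounds, and the source may have more. Where it says the series, first, only, none or still open, it means among the compounds named here.

Compound 1 `CC(C)c1cccc(C2CNCC2C(=O)Nc2cc3cc[nH]c(=O)c3cc2Cl)c1` gives 6 nM in an assay on isolated protein for inhibition of Rho-associated protein kinase 2 (Homo sapiens), read by a luciferase reporter; a higher number here means a weaker inhibitor, a lower number a stronger inhibitor. Compound 2 `O=C(Nc1cc2cc[nH]c(=O)c2cc1Cl)C1CNCCC1c1ccccc1` gives 6 nM in this assay, the same number at the digits shown, so the two stand level and together at the low end of the three measured values. Compound 3 `NC(C(=O)Nc1cc2cc[nH]c(=O)c2cc1Cl)c1cccc(Cl)c1` gives 15 nM in this assay, a higher number than compound 1 and beyond the usual scatter. Compound 1 thus sits with compound 2 at the low end of what has been measured, but cannot be set apart from compound 2.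

Compound 4 `O=C(Nc1cc2cc[nH]c(=O)c2cc1Cl)C1CNCC1c1cccc(Br)c1` is the next entry and differs from compound 1 in one place: bromo in place of isopropyl on an aromatic carbon. Put one bond further out, the change reads 3-isopropylphenyl to 3-bromophenyl. Among the compounds with values here, no pair among the measured compounds isolates this change, so there is no measured step to lean on. The values of compound 2 and compound 3 only show that an unsubstituted phenyl and a chloro-bearing phenyl on other linkers both stay within a narrow band. The step from compound 1 to compound 4 is expected to be a 1.3-fold higher number from compound 1 to compound 4 (0.12 log units; within the scatter), that is, none beyond the scatter. Compound 4 is estimated at 8 nM in this assay, with a likely range from 3 nM to 22 nM.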

Compound 4, half-maximal inhibitory concentration: 2 nM
Compound 4: the middle estimate sits 4.0-fold (0.60 log units) above what was measured, outside the stated range (below it).
By their numbers in this assay, from the lowest: compound 4; then compounds 1 and 2 (each within the scatter of the next); then compound 3.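

Within the data shown here, at the aromatic carbon meta to a large group, the change from 3-isopropylphenyl to 3-bromophenyl gives the first readable step in this assay, a 3.0-fold lower number from compound 1 to compound 4 (0.48 log units; beyond the scatter), so what this position carries does move the number. The step runs toward the lower number as three carbon heavy atoms give way to a single bromine, with compound 4 at 2 nM, which shows that the isopropyl group is not required for a low value here and can be replaced with a gain beyond the scatter. No measurement at hand bears on why the number falls with this exchange.

With a single pair, the compounds shown cannot separate an effect of having bromine at this position from one of losing the isopropyl group, and they give no trend across substituents, a gap that a methyl, a methoxy, a trifluoromethyl or an amine on the same carbon would help to fill. Also open, as far as these compounds go, is whether the bromo-for-isopropyl step would carry over to the other linkers, since neither of the two remaining compounds has a partner differing from it in one place.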